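A Flat Series Meets a 4-Chlorophenyl Group

The source may report more compounds than this note shows. Statements on the series, on what has been measured and on what is new or still open speak of the compounds shown alone.

Of the compounds shown here, three that share one core have been tested so far. In a functional assay on HCT-116 cells (Homo sapiens) for cytotoxicity, read by sulforhodamine B assay, with a stated time of 24 h (a higher number here means a weaker inhibitor, a lower number a stronger inhibitor), compound 1 (`O=C1Nc2ccc(S(=O)(=O)N3CCOCC3)cc2/C1=N/c1ccc(O)cc1`) gives 27300 nM while compound 2 (`CC(=O)N/N=C1\C(=O)Nc2ccc(S(=O)(=O)N3CCOCC3)cc21`) gives 29000 nM and compound 3 (`CC(=O)c1cccc(/N=C2\C(=O)Nc3ccc(S(=O)(=O)N4CCOCC4)cc32)c1`) gives 29000 nM on the same read-out. Compound 3 therefore stands level with compound 2 and within the scatter of compound 1.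

The next compound is compound 4 (`O=C1Nc2ccc(S(=O)(=O)N3CCOCC3)cc2/C1=N/c1ccc(Cl)cc1`), which has 4-chlorophenyl in place of 3-acetylphenyl on a double-bonded nitrogen, a change counted as 4-chlorophenyl in place of 3-acetylphenyl on a double-bonded nitrogen in full. All three measured steps bear on it, as each swaps a group at that same place. Acetamido in place of 4-hydroxyphenyl gave a 1.1-fold higher number from compound 1 to compound 2 (0.03 log units; within the scatter) and 3-acetylphenyl in place of 4-hydroxyphenyl gave a 1.1-fold higher number from compound 1 to compound 3 (0.03 log units; within the scatter) while 3-acetylphenyl in place of acetamido gave no change at the digits printed from compound 2 to compound 3 (within the scatter) in turn. Within the data shown here, none of these steps left the scatter, but no measured compound holds the 4-chlorophenyl group, so that group itself remains untested. Taking compound 3 at 29000 nM as the starting point, the estimated result is a 1.1-fold lower number from compound 3 to compound 4 (0.05 log units; within the scatter) and no shift beyond the scatter is expected. Compound 4 is estimated at 26000 nM with an expected range of 13000 nM to 45000 nM until a measurement settles it.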

Compound 4, half-maximal inhibitory concentration: 24300 nM
Beside the measured number, compound 4's estimate is 1.1-fold (0.03 log units) above it; measured number inside the range.
By their numbers in this assay, from the lowest: compounds 4, 1, 2 and 3 (each within the scatter of the next).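

Replacing the group on the double-bonded nitrogen gives a 1.2-fold lower number from compound 3 to compound 4 (0.08 log units; within the scatter) and a 1.2-fold lower number from compound 2 to compound 4 (0.08 log units; within the scatter) in this assay while chloro in place of hydroxy on an aromatic carbon gives a 1.1-fold lower number from compound 1 to compound 4 (0.05 log units; within the scatter) and all three steps stay within the scatter. This extends the flat picture at this position to a chlorine-bearing group, and the exchange of 3-acetylphenyl for 4-chlorophenyl shows that going from a group with one hydrogen-bond acceptor to a group with none, and from nine heavy atoms to seven, leaves the number within the scatter. Nothing on hand accounts for this lack of response, so the flatness stands only as an observation.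

On these data alone, whether an amine or a carboxylic acid on the aromatic ring, or a longer chain in its place, would take the number outside the scatter remains open. All four compounds also share the same core, so they cannot tell whether a change elsewhere in that core would move the number, or whether this position would stay as flat alongside such a change.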